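This account rests on a few compounds, and the source may have more. Where it says the series, first, only, none or still open, it means among the compounds named here.

Working notes on the series. Compound 1 `CN1CCN(c2cc(Nc3ncc(Br)c(Nc4cccc(CO)c4)n3)cc(S(C)(=O)=O)c2)CC1` is the higher of the two compounds measured in a physicochemical assay for lipophilicity, using the shake flask method, in phosphate buffer, measured as octanol-water partition, with a stated time of 5 h, at pH 7.4; on this read-out higher numbers stand for higher lipophilicity and lower numbers for lower lipophilicity: compound 1 gives 2.43, whereas compound 2 `Cc1cnc(Nc2cc(N3C[C@@H](C)N[C@@H](C)C3)cc(S(C)(=O)=O)c2)nc1Nc1cccc(CO)c1` gives 1.24, a gap beyond the usual scatter. Among the compounds with values here, no pair differing in a single place has been measured. Compound 3 `CN1CCN(c2cc(Nc3ncc(F)c(Nc4cccc(CO)c4)n3)cc(S(C)(=O)=O)c2)CC1` is still to be measured; it differs from compound 1 by fluoro in place of bromo on an aromatic carbon. For this change a downward step in this assay beyond the scatter is expected, estimated as a number 0.78 log units lower from compound 1 to compound 3 (beyond the scatter). Compound 3 is accordingly expected to give about 1.65, within a range of 1.2 to 2.1.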

Compound 3, distribution coefficient: 1.84
Compound 3: middle estimate off by 0.19 log units, on the low side, within the range that was stated.
By their numbers in this assay, from the lowest: compound 2; then compound 3; then compound 1.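

On the aromatic carbon para to a large group and ortho to the (3-(hydroxymethyl)phenyl)amino group, fluoro in place of bromo gives a number 0.59 log units lower from compound 1 to compound 3 (beyond the scatter) in this assay for the first pair differing in one place. The halogen at this position therefore matters on this read-out, at least on the core of compound 1. Within the data shown here, nothing measured so far accounts for the size of this step.

Open, from the compounds shown here alone, is where chloro or a nitrile at this position would land relative to fluoro and bromo. Also open, going by these compounds, is whether the step holds with another amine in place of the methylpiperazine.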